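Cyclobutyl for 4-hydroxycyclohexyl on the amide

The compounds below may be only part of what the source reports. "The series", "measured", "known", "first", "only" and "open" are said of these compounds alone.

Going by the values given here, in an ADME assay on MRC5 cells (Homo sapiens) for inhibition, with a stated time of 72 h (on this read-out higher numbers stand for an effect only at larger amounts of compound and lower numbers for an effect already at smaller amounts), compound 2 `COc1cccc(OC)c1C(=O)Nc1c[nH]nc1C(=O)N[C@H]1CC[C@H](O)CC1` gives 34000 nM, the only exact number available so far. Compound 1 `COc1cccc(OC)c1C(=O)Nc1c[nH]nc1C(=O)NC1CC1` gives > 50000 nM, which is a limit of the assay. Compound 3 `COc1cccc(OC)c1C(=O)Nc1c[nH]nc1C(=O)NC1CCC1` has not yet been measured. It carries cyclobutyl in place of 4-hydroxycyclohexyl on an amide-type nitrogen, and the difference from compound 2 counts as cyclobutyl in place of 4-hydroxycyclohexyl on an amide-type nitrogen. Among the compounds with values here, one measured step bears on this change, the replacement of cyclopropyl by 4-hydroxycyclohexyl at the same place: an at least 1.4-fold lower number from compound 1 to compound 2 (0.16 log units; that floor lies within the scatter). That small step gives little reason to expect a large one here, so a slightly higher number or none beyond the scatter is expected in this assay. The expected change is a 1.3-fold higher number from compound 2 to compound 3 (0.12 log units; within the scatter). For compound 3 the estimated value is 45000 nM, with an expected range of 20000 nM to 90000 nM.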

Compound 3, half-maximal effective concentration: > 50000 nM
Compound 3: no number, only a limit; the forecaster's own chance of this, stated with the estimate: 50%; middle value at least 1.1-fold (0.04 log units) from the limit.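

In this assay compound 3 gives > 50000 nM, which is a limit of the assay and not a number. Cyclobutyl in place of 4-hydroxycyclohexyl on the amide-type nitrogen amounts to an at least 1.4-fold higher number from compound 2 to compound 3 (0.16 log units; that floor lies within the scatter), so this change, like the earlier one with cyclopropyl, does not separate the compounds beyond the scatter. The step between compound 1 and compound 3 cannot be read, and the only exact number at this position still belongs to compound 2, which leaves the comparison bounded by a single feature of the data: the limit of > 50000 nM in this assay, at which 2 of the 3 values shown sit.

As far as these compounds go, how far the true values of compound 1 and compound 3 lie from that limit remains open. Also open, from the compounds shown here alone, is whether plain cyclohexyl, or a cyclohexyl ring carrying an amine or a carboxylic acid, would give an exact number on this amide-type nitrogen.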